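A few compounds are considered here, and "the series" means these few. Any claim that something is new, unique, unknown or untested is made for them only; others in the source may bear on it.

Measured compounds:
compound 1 `Cc1ccc(S(=O)(=O)N(Cc2cn(Cc3ccc(F)cc3)nn2)Cc2c(-c3ccccc3)c3ccccc3n2S(=O)(=O)c2ccc(C)cc2)cc1` gives -7.6%
compound 2 `Cc1ccc(S(=O)(=O)N(Cc2cn(Cc3ccccc3Cl)nn2)Cc2cn(S(=O)(=O)c3ccc(C)cc3)c3ccccc23)cc1` gives -4.8%
compound 3 `Cc1ccc(S(=O)(=O)n2cc(CN(Cc3cccc(F)c3F)C(=O)C(F)(F)F)c3ccccc32)cc1` gives -5.5%

All three numbers come from a functional assay on 3T3-L1 cells (Mus musculus) for inhibition, with a stated time of 20 min, tested at 20 uM; on this read-out lower numbers stand for less inhibition and higher numbers for more inhibition at the one concentration tested (going by the name of the read-out). Compound 2 stands alongside compound 3 and compound 1: its gap to compound 3 is within the scatter, and its gap to compound 1 is also within the scatter. Among the compounds with values here, no compound of the three shows inhibition beyond the noise of this assay, and no step between measured compounds is computed that differ in one place, so nothing shows how any single change moves the read-out.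

Compound 4 `COc1ccc(Cn2cc(CN(Cc3cn(S(=O)(=O)c4ccc(C)cc4)c4ccccc34)S(=O)(=O)c3ccc(C)cc3)nn2)c(OC)c1` is not yet measured. It differs from compound 2 by one change: 2,4-dimethoxyphenyl in place of 2-chlorophenyl on a saturated chain carbon bound to an aromatic nitrogen. Within the data shown here, the measured set gives no precedent for this change, and the three numbers sit together near zero. The expectation is therefore that the step of a number 0.8 percentage points higher from compound 2 to compound 4 (within the scatter) stays within the scatter, in no particular direction. The number for compound 4 is estimated at -4%, with a range from -15% to 7%.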

Compound 4, a percentage reported as inhibition, at one concentration (the size of the read-out at that concentration, not a potency): 7.6%
Compound 4: middle estimate off by 11.6 percentage points, on the low side; the measured number lies above the stated range.
By their numbers in this assay, from the lowest: compounds 1, 3 and 2 (each within the scatter of the next); then compound 4.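

In this assay, within the data shown here, 2,4-dimethoxyphenyl in place of 2-chlorophenyl on a saturated chain carbon bound to an aromatic nitrogen gives a number 12.4 percentage points higher from compound 2 to compound 4 (beyond the scatter), the first single change that can be read. Among these compounds, the earlier compounds, all within the scatter of one another, could not show that any position responds, whereas this one clearly does respond to the group it carries, though only this one change supports that. Nothing at hand bears on why the read-out moves with this change.

Still open, as far as these compounds go, is whether the step follows from gaining the two methoxy groups or from losing the chlorine, and whether it carries over to the core of compound 1. From the compounds shown here alone, how a carboxylic acid or a dimethylamino group would read at this place also remains open.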